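This account rests on a few compounds, and the source may have more. Where it says the series, first, only, none or still open, it means among the compounds named here.

Series notes. Compound 1 `COc1cc(C(F)(F)F)cc(SC)c1C(=O)NC1(c2ccc(Cl)cc2)CCCN(C)C1` gives 28 nM in an assay on cells for inhibition of sodium- and chloride-dependent glycine transporter 1 (Homo sapiens); on this read-out lower numbers stand for an effect already at smaller amounts and higher numbers for an effect only at larger amounts of compound. Compound 2 `COc1cc(C(F)(F)F)cc(SC)c1C(=O)NC1(c2ccc(C)cc2)CCCN(C)C1` gives 230 nM, and compound 3 `COc1cc(C(F)(F)F)cc(SC)c1C(=O)NC1(c2ccncc2)CCCN(C)C1` gives 60 nM. Among the three numbers compound 3 therefore stands second highest, nearer to compound 1 than to compound 2. Compound 4 `COc1cc(C(F)(F)F)cc(SC)c1C(=O)NC1(c2cnccn2)CCCN(C)C1` is not yet measured; it differs from compound 3 by pyrazin-2-yl in place of pyridin-4-yl on a saturated ring carbon. The measured steps that bear on this are the two that also exchange the group on the saturated ring carbon: a 2.1-fold higher number from compound 1 to compound 3 (0.33 log units; beyond the scatter) and a 3.8-fold lower number from compound 2 to compound 3 (0.58 log units; beyond the scatter), both modest and both beyond the scatter. Exchanging one six-membered aromatic group for another at this carbon has so far moved the number by a modest amount in either direction, so a further modest step is expected here, most likely toward a somewhat higher number, though a result within the scatter cannot be ruled out. The expected step is a 1.7-fold higher number from compound 3 to compound 4 (0.22 log units; within the scatter). Compound 4 is accordingly estimated at 100 nM, within the range 35 nM to 300 nM.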

Compound 4, half-maximal effective concentration: 1670 nM
Beside the measured number, compound 4's estimate is 17-fold (1.22 log units) below it; the whole stated range lies below it.
By their numbers in this assay, from the lowest: compound 1; then compound 3; then compound 2; then compound 4.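

Working notes: in (this assay) the exchange at this saturated ring carbon is not always modest, since pyrazin-2-yl in place of pyridin-4-yl gives (a 28-fold higher number from compound 3 to compound 4 (1.44 log units; beyond the scatter)) and is the first large step among the aromatic groups here. The pyrazin-2-yl compound also stands apart from the two phenyl compounds, with (a 7.3-fold higher number from compound 2 to compound 4 (0.86 log units; beyond the scatter)) and (a 60-fold higher number from compound 1 to compound 4 (1.78 log units; beyond the scatter)) as the steps, so a ring nitrogen alone does not set the number: pyridin-4-yl stays close to 4-chlorophenyl, while pyrazin-2-yl does not. Nothing shown gives a reason for the large step.

Still open, on these data alone, is whether the second ring nitrogen or the place of attachment drives the change, which pyridin-2-yl and pyrimidin-5-yl at this carbon could separate. Also open, as far as these compounds go, is how a saturated group such as cyclohexyl would fare there.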